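A few compounds are considered here, and "the series" means these few. Any claim that something is new, unique, unknown or untested is made for them only; others in the source may bear on it.

In a functional assay on CCRF-CEM cells (Homo sapiens) for inhibition, read by MTT assay, with a stated time of 72 h (on this read-out higher numbers stand for weaker inhibition and lower numbers for stronger inhibition), compound 1 (`C=C(Br)C(=O)Nc1cccc(/C=C/C(=O)Nc2cccc3ccccc23)c1`) gives 1800 nM, compound 2 (`C=C(Br)C(=O)Nc1cccc(/C=C/C(=O)Nc2ccc(F)cc2)c1`) gives 16600 nM and compound 3 (`C=C(Br)C(=O)Nc1cccc(/C=C/C(=O)Nc2ccc(Cl)cc2)c1`) gives 460 nM. Compound 2 therefore has the highest number of the three and is the weakest inhibitor among them. Compound 4 (`C=C(Br)C(=O)Nc1cccc(/C=C/C(=O)NCc2ccc(C)cc2)c1`) has not yet been measured. Its difference from compound 2 is 4-methylbenzyl in place of 4-fluorophenyl on an amide-type nitrogen, with 4-methylbenzyl in place of 4-fluorophenyl on an amide-type nitrogen. Among the compounds with values here, no measured compound carries a benzyl group, so the evidence is indirect. Within the data shown here, the one measured single change is a 36-fold lower number from compound 2 to compound 3 (1.56 log units; beyond the scatter), a large step with chloro in place of fluoro on an aromatic carbon. Compound 1, at 1800 nM, also lies well under compound 2. Since both neighbours lie lower, a move away from compound 2 is expected to lower the number, though by an uncertain amount. The expected change is an estimated 5.5-fold lower number from compound 2 to compound 4 (0.74 log units; beyond the scatter), a clear step towards stronger inhibition. For compound 4 the estimate is 3000 nM, with an expected range of 700 nM to 13000 nM.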

Compound 4, half-maximal inhibitory concentration: 550 nM
Beside the measured number, compound 4's estimate is 5.5-fold (0.74 log units) above it; the whole stated range lies above it.
By their numbers in this assay, from the lowest: compounds 3 and 4 (each within the scatter of the next); then compound 1; then compound 2.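

In this assay, the amide-type nitrogen is shown to tolerate a benzyl group as well as a directly attached aromatic ring: 4-methylbenzyl in place of 4-fluorophenyl gives a 30-fold lower number from compound 2 to compound 4 (1.48 log units; beyond the scatter), a large step towards stronger inhibition. With a 1.2-fold higher number from compound 3 to compound 4 (0.08 log units; within the scatter), which lies within the scatter, 4-methylbenzyl and 4-chlorophenyl cannot be told apart, so two different groups on this nitrogen reach the same level. Compound 2, with 4-fluorophenyl, therefore stays the one clearly high number among the groups shown here. Nothing in the available data explains these differences. Because the change swaps the whole group, the compounds leave open how much of the step belongs to the benzyl carbon and how much to the methyl. Plain benzyl, 4-fluorobenzyl or a longer chain such as 2-phenylethyl would separate these contributions.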